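Removing a methyl from the pyridine ring of compound 2

This account rests on a few compounds, and the source may have more. Where it says the series, first, only, none or still open, it means among the compounds named here.

Measured so far:
compound 1 `CCc1cc(C(=O)N[C@@H](C)c2nc(-c3cccc(C)c3)no2)n(C)n1` — 335 nM
compound 2 `Cc1cncc(-c2noc([C@H](C)NC(=O)c3cc(C(F)(F)F)nn3C)n2)c1` — 1370 nM

In an assay on T-REx-293 cells for inhibition of potassium channel subfamily T member 1 (Homo sapiens), read by patch clamp (on this read-out higher numbers stand for weaker inhibition and lower numbers for stronger inhibition), compound 2 gives 1370 nM, the highest of the two numbers; compound 1 gives 335 nM, a lower number beyond the scatter. Compound 3 `C[C@H](NC(=O)c1cc(C(F)(F)F)nn1C)c1nc(-c2cccnc2)no1` is not yet measured. It differs from compound 2 by hydrogen in place of methyl on an aromatic carbon, that is, 5-methylpyridin-3-yl becomes pyridin-3-yl. For the measured compounds named here, no measured pair shows this change, so the expected step of a 1.1-fold higher number from compound 2 to compound 3 (0.04 log units; within the scatter) is small, possibly within the scatter. Compound 3 is therefore expected to give about 1500 nM, within 600 nM to 4000 nM.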

Compound 3, half-maximal inhibitory concentration: 11800 nM
Beside the measured number, compound 3's estimate is 7.9-fold (0.90 log units) below it, and the stated range ends below it.
By their numbers in this assay, from the lowest: compound 1; then compound 2; then compound 3.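

In this assay, replacing the methyl on this ring with hydrogen gives an 8.6-fold higher number from compound 2 to compound 3 (0.94 log units; beyond the scatter), so inhibition weakens. This shows that a single carbon at this place, two atoms from the ring nitrogen and meta to a large group, can shift the number well beyond the scatter. Nothing available here explains why the methyl matters.

From the compounds shown here alone, whether an ethyl, a methoxy or a chlorine at this place would match or improve on the methyl remains open. So does whether removing the methyl from the aromatic ring of compound 1 would have a similar effect.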